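Swapping 4-Methoxyphenyl for Furan-2-yl on a Shared Core

A few compounds are considered here, and "the series" means these few. Any claim that something is new, unique, unknown or untested is made for them only; others in the source may bear on it.

In a functional assay on MGC-803 cells (Homo sapiens) for cytotoxicity, read by MTT assay, with a stated time of 72 h (on this read-out lower numbers stand for stronger inhibition and higher numbers for weaker inhibition), compound 2 `COc1ccc(C=C2C(=O)N(c3ccc(Cl)cc3)N(c3ccc(Cl)cc3)C2=O)cc1` gives > 128000 nM, which is a limit of the assay and not a number. Its standing therefore rests on (the limit of > 128000 nM in this assay, at which 1 of the 3 values shown sits). The two other measured compounds share its core and give real numbers: compound 1 `CCC(C)=C1C(=O)N(c2ccc(Cl)cc2)N(c2ccc(Cl)cc2)C1=O` gives 66500 nM, and compound 3 `CC(=C1C(=O)N(c2ccc(Cl)cc2)N(c2ccc(Cl)cc2)C1=O)c1ccc(O)cc1` gives 42800 nM.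

The next compound is compound 4 `O=C1C(=Cc2ccco2)C(=O)N(c2ccc(Cl)cc2)N1c1ccc(Cl)cc1`, in which furan-2-yl takes the place of 4-methoxyphenyl on a double-bonded chain carbon bound to a double-bonded ring carbon: furan-2-yl in place of 4-methoxyphenyl on a double-bonded chain carbon bound to a double-bonded ring carbon. Among the measured compounds shown here, no measured step makes this exact swap. The closest is a 1.6-fold lower number from compound 1 to compound 3 (0.19 log units; within the scatter), where 4-hydroxyphenyl replaces ethyl on a double-bonded chain carbon. That step is small, so it offers no support for a large change from swapping a group in this region. Because compound 2 sits at > 128000 nM, any measurable number for compound 4 would have to fall on the lower side of that limit, and a second limit remains possible.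

The expected change is modest and points towards a lower number: an at least 1.6-fold lower number from compound 2 to compound 4 (0.20 log units; that floor lies within the scatter). For compound 4, the estimated value is 80000 nM, with an expected range from 30000 nM to 170000 nM.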

Compound 4, half-maximal inhibitory concentration: 12800 nM
The estimate for compound 4 lay 6.3-fold (0.80 log units) above the measured number; measured number below the stated range.
By their numbers in this assay, from the lowest: compound 4; then compounds 3 and 1 (each within the scatter of the next). At a limit, above all of these: compound 2.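

In this assay, among the compounds shown here, furan-2-yl in place of 4-methoxyphenyl gives an at least 10-fold lower number from compound 2 to compound 4 (1.00 log units; beyond the scatter), the first step that lies beyond the scatter. This shows that the group on a double-bonded chain carbon bound to a double-bonded ring carbon can change the read-out clearly, which the earlier step, a 1.6-fold lower number from compound 1 to compound 3 (0.19 log units; within the scatter), gave no sign of. The full size of the new step stays unknown, because compound 2 stands at a limit of the assay and not at a number: the limit of > 128000 nM in this assay, at which 1 of the 4 values shown sits.

This swap changes several things at once: 4-methoxyphenyl has 8 heavy atoms and a six-membered aromatic ring of carbon only, while furan-2-yl has 5 heavy atoms and a five-membered aromatic ring with 1 hetero atom, and one pair of compounds cannot separate these differences. Going by these compounds, it remains open whether a plain phenyl or a thiophen-2-yl group in this place would give a number close to that of compound 4, or whether furan-2-yl is needed.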